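The source may hold more compounds than are shown below. What is called first, only, known or untested is meant among the compounds shown, and "the series" means these compounds.

Measured so far:
compound 1 `COc1cc2ncnc(Nc3ccc(F)c(Cl)c3)c2cc1NC(=O)/C=C/c1ccc(F)cc1Cl`: "not determined" (no result reported)
compound 2 `COc1ccc(/C=C/C(=O)Nc2cc3c(Nc4ccc(F)c(Cl)c4)ncnc3cc2O[C@H]2CCOC2)c(OC)c1`: 26500 nM
compound 3 `COc1cc2ncnc(Nc3ccc(F)c(Cl)c3)c2cc1NC(=O)/C=C/c1ccccc1[N+](=O)[O-]`: "not determined" (no result reported)

Among the measured compounds shown here, in a functional assay on HeLa cells (Homo sapiens) for cytotoxicity, read by MTT assay, with a stated time of 72 h (on this read-out lower numbers stand for stronger inhibition and higher numbers for weaker inhibition), compound 2 gives 26500 nM, the only number in the set. For the measured compounds named here, compound 1 stands at "not determined" (no result reported) in this assay, and compound 3 stands at "not determined" (no result reported), so no step between measured compounds can be read and no trend is known. Compound 4 `COc1ccc(/C=C/C(=O)Nc2cc3c(Nc4ccc(F)c(Cl)c4)ncnc3cc2O[C@H]2CCOC2)cc1` is the next entry for this assay. It differs from compound 2 by hydrogen in place of methoxy on an aromatic carbon. Without any measured step to lean on, the change is expected to be small, of no clear direction and probably within the scatter, so the step expected is a 1.1-fold higher number from compound 2 to compound 4 (0.05 log units; within the scatter). Compound 4 is accordingly estimated at 30000 nM in this assay, with a range of 10000 nM to 90000 nM.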

Compound 4, half-maximal inhibitory concentration: 34600 nM
Estimate against measurement, compound 4: 1.2-fold (0.06 log units) below, within the range that was stated.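

In this assay, hydrogen in place of methoxy on this aromatic carbon, ortho to a large group, gives a 1.3-fold higher number from compound 2 to compound 4 (0.12 log units; within the scatter). Among the compounds shown here, this is the first readable step: going from 2,4-dimethoxyphenyl to 4-methoxyphenyl leaves the two compounds indistinguishable in this read-out. No supporting data bear on why this is so.

Still open, going by these compounds, is whether an amine or a carboxylic acid at this carbon would separate from methoxy and hydrogen. The contribution of the remaining methoxy group also stays unknown, with no step at that place shown.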